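Swapping Chloro for Dimethylamino on the Benzamide Ring

The compounds below may be only part of what the source reports. "The series", "measured", "known", "first", "only" and "open" are said of these compounds alone.

Compound 2 `CC(/C=N/Nc1ccc([N+](=O)[O-])cc1)=N\NC(=O)c1ccc(Cl)cc1` has the higher of the two numbers seen so far: in a functional assay on cells (Splenocyte, Mus musculus, strain BALB/c) for inhibition, read by scintillation counting and thymidine incorporation, with a stated time of 72 h (on this read-out lower numbers stand for stronger inhibition and higher numbers for weaker inhibition), compound 2 gives 4200 nM, whereas compound 1 `CC(/C=N/Nc1ccc([N+](=O)[O-])cc1)=N\NC(=O)c1ccc([N+](=O)[O-])cc1` gives 980 nM. Among the measured compounds shown here, the single measured step, a 4.3-fold higher number from compound 1 to compound 2 (0.63 log units; beyond the scatter), came from exchanging nitro for chloro on an aromatic carbon. Compound 3 `CC(/C=N/Nc1ccc([N+](=O)[O-])cc1)=N\NC(=O)c1ccc(N(C)C)cc1` differs from compound 2 by dimethylamino in place of chloro on an aromatic carbon. For the measured compounds named here, no measured step involves dimethylamino, so that one step only shows that the group at this position moves the number modestly. A step of a 1.4-fold higher number from compound 2 to compound 3 (0.15 log units; within the scatter) in this assay is therefore expected, giving compound 3 an estimated 6000 nM (range 1500 nM to 25000 nM).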

Compound 3, half-maximal inhibitory concentration: > 12000 nM
Compound 3: no number, only a limit; the forecaster's own chance of this, stated with the estimate: 15%; middle value at least 2.0-fold (0.30 log units) away from the limit.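

Compound 3 gives no exact number, only a limit: the limit of > 12000 nM in this assay, at which 1 of the 3 values shown sits. Among the compounds shown here, the group at this position can therefore move the number much further than the one earlier step showed, with an at least 2.8-fold higher number from compound 2 to compound 3 (0.45 log units; beyond the scatter) and an at least 12-fold higher number from compound 1 to compound 3 (1.08 log units; beyond the scatter). Across these three compounds, nitro gives the lowest number, chloro an intermediate one and dimethylamino the highest reading.

From the compounds shown here alone, how far compound 3 lies past its limit remains open, and so does the full size of both steps. Where a methyl group or a carboxylic acid at this position would fall is also unknown.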